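The compounds below may be only part of what the source reports. "The series", "measured", "known", "first", "only" and "open" are said of these compounds alone.

Working notes on the series, the sulfonamide piperidine set. Three compounds have a number in a functional assay on MIA PaCa-2 cells (Homo sapiens) for inhibition, read by MTT assay, with a stated time of 7 days; on this read-out lower numbers stand for stronger inhibition and higher numbers for weaker inhibition. Compound 1, `CCN(CC)S(=O)(=O)c1ccc(S(=O)(=O)N2CCC[C@@H](C(=O)NC3CN(C(=O)C4CC4)C3)C2)cc1`, gives 2800 nM. Compound 2, `CCN(CC)S(=O)(=O)c1ccc(S(=O)(=O)N2CCC[C@@H](C(=O)N(C)C(C)C)C2)cc1`, gives 6200 nM, the highest of the three numbers; its nearest neighbour is compound 3, `CCN(CC)S(=O)(=O)c1ccc(S(=O)(=O)N2CCC[C@@H](C(=O)NC3CN(C(=O)NC(C)(C)C)C3)C2)cc1`, which gives 3400 nM. The step of a 2.2-fold higher number from compound 1 to compound 2 (0.35 log units; beyond the scatter) is the only one of the three that falls beyond the scatter; a 1.2-fold higher number from compound 1 to compound 3 (0.08 log units; within the scatter) and a 1.8-fold lower number from compound 2 to compound 3 (0.26 log units; within the scatter) both stay within it.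

Compound 4, `CCN(CC)S(=O)(=O)c1ccc(S(=O)(=O)N2CCC[C@@H](c3cc(C)no3)C2)cc1`, has not yet been measured. Its difference from compound 2 is 3-methyl-1,2-oxazol-5-yl in place of isopropyl(methyl)carbamoyl on a saturated ring carbon. Going by the values given here, the steps measured so far, a 2.2-fold higher number from compound 1 to compound 2 (0.35 log units; beyond the scatter) and a 1.8-fold lower number from compound 2 to compound 3 (0.26 log units; within the scatter), each alter only the group on the carbonyl carbon and keep the carbonyl itself; no measured pair swaps the carbonyl for a five-membered aromatic ring with 2 hetero atoms, so they bear on the present change only loosely. Among the compounds with values here, since every step so far stayed near the scatter, a modest step in this assay is expected for compound 4, with no firm direction. The estimate for compound 4 is 5000 nM, within 1500 nM to 16000 nM, which is expected to mean a step of a 1.2-fold lower number from compound 2 to compound 4 (0.09 log units; within the scatter).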

Compound 4, half-maximal inhibitory concentration: 4900 nM
The estimate for compound 4 lay 1.0-fold (0.01 log units) above the measured number, within the range that was stated.
By their numbers in this assay, from the lowest: compounds 1, 3, 4 and 2 (each within the scatter of the next, the first and the last beyond it).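

Swapping isopropyl(methyl)carbamoyl for 3-methyl-1,2-oxazol-5-yl on the saturated ring carbon gives a 1.3-fold lower number from compound 2 to compound 4 (0.10 log units; within the scatter) in this assay and is the first change in the series that removes the carbonyl at this position rather than altering the group attached to it. At this position, then, the read-out for this pair stays within the scatter with the carbonyl gone and a five-membered aromatic ring with 2 hetero atoms in its place, so the carbonyl is not needed for a number in this range, at least when the 1,2-oxazole takes its place. Nothing available on either group explains this result.

The compounds shown leave open how a carboxylic acid, a primary amine or a longer alkyl chain would read on this ring carbon, as the only groups compared here are the carbonyl-linked ones and this single aromatic ring. Going by these compounds alone, they also leave open whether the methyl on the 1,2-oxazole ring matters, as no compound here carries that ring without the methyl or with an ethyl in its place.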